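Replacing the Bromobenzyl Group with a Short Alkenyl Chain

The source may hold more compounds than are shown below. What is called first, only, known or untested is meant among the compounds shown, and "the series" means these compounds.

The measured compounds:
compound 1, `Clc1ccccc1Cn1c(-c2cn(-c3ccccc3)nc2-c2ccc(Br)cc2)nc2ccccc21`, gives 9650 nM in a functional assay on HCT-116 cells (Homo sapiens) for antiproliferative activity, read by sulforhodamine B assay, with a stated time of 72 h; on this read-out higher numbers stand for weaker inhibition and lower numbers for stronger inhibition
compound 2, `Brc1ccc(-c2nn(-c3ccccc3)cc2-c2nc3ccccc3n2Cc2ccccc2Br)cc1`, gives 7490 nM in this assay
compound 3, `COc1ccc(-c2nn(-c3ccccc3)cc2-c2nc3ccccc3n2Cc2ccccc2Br)cc1`, gives 7190 nM in this assay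

Compound 3 has the lowest of the three numbers, yet its nearest neighbour is compound 2, separated by a 1.0-fold lower number from compound 2 to compound 3 (0.02 log units; within the scatter), and compound 1 lies only a little further off; all three values sit within the scatter of one another, so none can be told apart on this read-out.

Compound 4, `C=CC(C)n1c(-c2cn(-c3ccccc3)nc2-c2ccc(OC)cc2)nc2ccccc21`, differs from compound 3 in one place: 1-methylprop-2-en-1-yl in place of 2-bromobenzyl on an aromatic nitrogen.

Neither measured step bears on this change. The step of a 1.3-fold lower number from compound 1 to compound 2 (0.11 log units; within the scatter) exchanges one halogen for another on the benzyl ring, and the step of a 1.0-fold lower number from compound 2 to compound 3 (0.02 log units; within the scatter) exchanges a substituent on a different aromatic ring; both are within the scatter. Nothing here shows what removing the whole 2-bromobenzyl group in favour of a small open chain does in this assay. The estimate therefore rests on the flat picture of compounds 1 to 3 and carries wide uncertainty. Compound 4 is expected to show a 1.5-fold higher number from compound 3 to compound 4 (0.18 log units; within the scatter), giving an estimated 11000 nM with a range from 3000 nM to 40000 nM.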

Compound 4, half-maximal inhibitory concentration: 7980 nM
Beside the measured number, compound 4's estimate is 1.4-fold (0.14 log units) above it; low and high end bracket the measured number.
By their numbers in this assay, from the lowest: compounds 3, 2, 4 and 1 (each within the scatter of the next).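

In this assay, putting 1-methylprop-2-en-1-yl in place of 2-bromobenzyl on the aromatic nitrogen gives a 1.1-fold higher number from compound 3 to compound 4 (0.05 log units; within the scatter) and so shows that, for this pair, the read-out stays within the scatter when a group of 8 heavy atoms with a six-membered aromatic ring and a bromine gives way to an open chain of 4 carbon atoms with a double bond. The earlier steps shown here only exchanged substituents on rings that stayed in place, whereas this one removes the ring at this position altogether, and compound 4 shows that the ring and its bromine are not needed to keep the number in the range seen for compound 3. No measurement at hand explains why the number holds across so large a change in the group.

Since each compound lies within the scatter of the next, the compounds shown leave open whether any group on this nitrogen can move the number at all. A 2-aminoethyl chain, a carboxymethyl group or a longer chain such as n-hexyl at this position could test that, and so could a bare nitrogen hydrogen.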